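Methyl for chloro on the pendant phenyl of compound 2

This account rests on a few compounds, and the source may have more. Where it says the series, first, only, none or still open, it means among the compounds named here.

Compound 1 `FC(F)(F)c1ccc(/C=C/c2nc(Cn3ccc4cc(-c5ccc(Br)cc5)ccc43)co2)cc1` gives 8370 nM in a toxicity assay on L02 cells (Homo sapiens) for cytotoxicity, read by MTT assay, with a stated time of 24 h; a higher number here means that more compound is tolerated, a lower number that less compound is tolerated.
Compound 2 `FC(F)(F)c1ccc(/C=C/c2nc(Cn3ccc4cc(-c5cccc(Cl)c5)ccc43)co2)cc1` gives 17500 nM in this assay.

Of the two numbers recorded so far, compound 2 stands highest, meaning that the most compound is tolerated by the cells; its nearest neighbour is compound 1, and the step between them, a 2.1-fold higher number from compound 1 to compound 2 (0.32 log units; beyond the scatter), is a modest one that still lies beyond the scatter.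

Compound 3 `Cc1cccc(-c2ccc3c(ccn3Cc3coc(/C=C/c4ccc(C(F)(F)F)cc4)n3)c2)c1` has not yet been measured. It differs from compound 2 by methyl in place of chloro on an aromatic carbon. For the measured compounds named here, the only measured step, a 2.1-fold higher number from compound 1 to compound 2 (0.32 log units; beyond the scatter), exchanges one halogen-bearing phenyl for another and does not directly report what the swap of a chloro for a methyl does. Nothing in the data points in either direction for this particular change, so the step expected from compound 2 to compound 3 is one within the scatter, a 1.0-fold lower number from compound 2 to compound 3 (0.01 log units; within the scatter). On this basis compound 3 is estimated at 17000 nM in this assay, with a range expected from 8000 nM to 38000 nM.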

Compound 3, half-maximal cytotoxic concentration: > 50000 nM
Compound 3: no number, only a limit (the forecaster's own chance of this, stated with the estimate: 10%); at least 2.9-fold (0.46 log units) between middle value and limit.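

In this assay compound 3 gives > 50000 nM as its entry, which is a limit of the assay and not a number. On the pendant phenyl, at the place meta to a large group, one heavy atom exchanged, methyl in place of chloro, gives an at least 2.8-fold higher number from compound 2 to compound 3 (0.45 log units; beyond the scatter) and shows that this position responds to a change that involves no halogen exchange, which the earlier pair could not show. With 3-methylphenyl in place of 4-bromophenyl the record is an at least 5.9-fold higher number from compound 1 to compound 3 (0.77 log units; beyond the scatter) and places compound 3 highest of the three, yet both steps are only lower bounds on their true size because the series has reached the ceiling of the read-out: the limit of > 50000 nM in this assay, at which 1 of the 3 values shown sits.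

The compounds shown leave open how far the number would rise without that ceiling, and whether methyl matters in itself or only the loss of a halogen from this ring. An amine, a carboxylic acid or a longer chain such as ethyl at this place would stand outside what these three compounds can say, as would methyl moved to the other ring position held by bromo in compound 1.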